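The source may hold more compounds than are shown below. What is called first, only, known or untested is meant among the compounds shown, and "the series" means these compounds.

Compound 1, `CCCCCCCCCCc1ccc(-c2noc(CCCN)n2)cc1`, stands highest of the three compounds measured in an assay on HeLa cells for inhibition of sphingosine-1-phosphate transporter SPNS2 (Mus musculus), read by LC-MS, tested at 2 uM (on this read-out higher numbers stand for more inhibition at the one concentration tested (going by the name of the read-out) and lower numbers for less inhibition), where compound 1 gives 67%. Compound 2, `CCCCCCCCCCc1ccc(-c2noc(CCCCN)n2)cc1`, gives 55% in this assay, a change of a number 12 percentage points lower from compound 1 to compound 2 (beyond the scatter) for aminomethyl in place of amino on a saturated chain carbon, three bonds along the chain from an aromatic carbon. Compound 3, `CCCCCCCCCCc1ccc(-c2noc([C@H]3CCC[C@@H](N)C3)n2)cc1`, gives 29%, and the step of a number 38 percentage points lower from compound 1 to compound 3 (beyond the scatter) comes with 3-aminocyclohexyl in place of 3-aminopropyl on an aromatic carbon; from compound 2 to compound 3 the step is a number 26 percentage points lower from compound 2 to compound 3 (beyond the scatter). Compound 4, `CCCCCCCc1ccc(-c2noc(CCCN)n2)cc1`, differs from compound 1 in hydrogen in place of propyl on a saturated chain carbon, seven bonds along the chain from an aromatic carbon. For the measured compounds named here, none of the measured steps touches this end of the molecule: all three alter the amine-bearing side, so none bears directly on the change at hand, and the expectation rests on compound 1 alone with a wide range. Compound 4 is therefore expected to give an estimated 50%, between 20% and 75%. The expected step is a number 17 percentage points lower from compound 1 to compound 4 (beyond the scatter), of uncertain direction.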

Compound 4, a percentage reported as inhibition, at one concentration (the size of the read-out at that concentration, not a potency): 52%
Compound 4: the middle estimate sits 2 percentage points below what was measured; the range from low to high includes it.
By their numbers in this assay, from the lowest: compound 3; then compounds 4 and 2 (each within the scatter of the next); then compound 1.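

In this assay, for the compounds shown here, hydrogen in place of propyl on a saturated chain carbon, seven bonds along the chain from an aromatic carbon, goes with a number 15 percentage points lower from compound 1 to compound 4 (beyond the scatter) and so shows that the far end of the chain, which the earlier steps left alone, does count on this read-out. The loss is only partial, since compound 4 still gives 52% with the shortened chain. Nothing measured here accounts for the drop.

As far as these compounds go, a single shortening gives one comparison and not a trend, so how the number moves with a butyl or pentyl group removed instead, or with a longer chain than that of compound 1, remains open. Also open, from the compounds shown here alone, is whether a phenyl group at the end of the chain could stand in for the propyl.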